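A few compounds are considered here, and "the series" means these few. Any claim that something is new, unique, unknown or untested is made for them only; others in the source may bear on it.

Compound 1 `O=C(Nc1cccc(-n2cc(-c3ccncc3)c(-c3ccc(Cl)c(O)c3)n2)c1)Nc1cccc(C(F)(F)F)c1` was measured in a functional assay on NCI-H226 cells (Homo sapiens) for inhibition, read by sulforhodamine B assay, with a stated time of 48 h; on this read-out lower numbers stand for stronger inhibition of growth and higher numbers for weaker inhibition of growth; there compound 1 gives > 32500 nM, which is a limit of the assay.
Compound 2 `O=C(Nc1cccc(-n2cc(-c3ccncc3)c(-c3ccc(Cl)c(O)c3)n2)c1)Nc1ccc(Cl)c(Cl)c1` was also measured, and in this assay compound 2 gives > 32500 nM, again a limit of the assay.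
Compound 3 `COc1cc(-c2nn(-c3cccc(NC(=O)Nc4ccc(Cl)c(C(F)(F)F)c4)c3)cc2-c2ccncc2)ccc1Cl` completes the measured set, and in this assay compound 3 gives > 32500 nM, once more a limit of the assay.

Compound 3 therefore stands at the limit and nowhere else on the numbers shown, with only a range and no fixed value. Compound 4 `O=C(Nc1cccc(-n2cc(-c3ccncc3)c(-c3ccc(Cl)c(O)c3)n2)c1)Nc1ccc(Cl)c(C(F)(F)F)c1` differs from compound 3 in one place: hydrogen in place of methyl on an oxygen on an aromatic ring, methoxy to hydroxy. Within the data shown here, only one measured step exists, a step that the two limits leave unreadable from compound 1 to compound 2, and it concerns a different position and is itself unreadable, so no measured step bears directly on the change from methoxy to hydroxy. What the set does show is the limit of > 32500 nM in this assay, at which 3 of the 3 values shown sit, and compound 1 and compound 2, which both carry the hydroxy group, sit at that limit. The account therefore expects no step beyond the scatter, and expects the step to be a step that the limit leaves unreadable from compound 3 to compound 4. For compound 4 the estimate is 50000 nM, with a range from 10000 nM to 250000 nM, and most likely only a limit will again be reported.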

Compound 4, concentration for total growth inhibition: > 32500 nM
Compound 4: a limit, no number (the forecaster's own chance of this, stated with the estimate: 85%); the middle value does not contradict the limit.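

Compound 4 also gives only a limit of the assay, so no step among compound 1, compound 2, compound 3 and compound 4 can be read: the limit of > 32500 nM in this assay, at which 4 of the 4 values shown sit.

The compounds shown leave open whether methoxy to hydroxy, or any other change among them, makes any difference in this assay.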